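This account rests on a few compounds, and the source may have more. Where it says the series, first, only, none or still open, it means among the compounds named here.

Measured in a functional assay on SMMC-7721 cells (Homo sapiens) for antiproliferative activity, read by MTT assay, with a stated time of 48 h; on this read-out higher numbers stand for weaker inhibition and lower numbers for stronger inhibition:
- compound 1 `CC(C)=CCC[C@]1(C)/C=C/[C@@H](OC(=O)C=C(C)C)[C@](C)(O)/C=C/C(=O)/C(CN2CCN(C)CC2)=C\C1`: 2940 nM
- compound 2 `CC(C)=CCC[C@]1(C)/C=C/[C@@H](OC(=O)C=C(C)C)[C@](C)(O)/C=C/C(=O)/C(CN=[N+]=[N-])=C\C1`: 3080 nM

In this assay, among the compounds with values here, compound 2 gives 3080 nM, and compound 1, its nearest neighbour and the only other compound measured, lies within the scatter of it. Compound 3 `CO/N=C/C1=C/C[C@](C)(CCC=C(C)C)/C=C/[C@@H](OC(=O)C=C(C)C)[C@](C)(O)/C=C/C1=O` has not yet been measured. It differs from compound 2 by a group of 4 heavy atoms (2 carbon, 1 nitrogen, 1 oxygen; no ring) in place of a group of 4 heavy atoms (1 carbon, 3 nitrogen; no ring), on a double-bonded ring carbon. The azidomethyl leaves, and the entering group sits on a double-bonded ring carbon of the shared core.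

Within the data shown here, only one measured step bears on this change: a 1.0-fold higher number from compound 1 to compound 2 (0.02 log units; within the scatter). That swap, azido in place of 4-methylpiperazin-1-yl, took place on a saturated chain carbon bound to a double-bonded ring carbon, and the saturated chain carbon stayed in both compounds. Among the measured compounds shown here, no measured step replaces that carbon, so the evidence is indirect and the range is kept wide. No shift beyond the scatter is expected, and the estimated step is a 1.0-fold lower number from compound 2 to compound 3 (0.01 log units; within the scatter). For compound 3 the expected value is 3000 nM, with an estimated range of 1000 nM to 9000 nM.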

Compound 3, half-maximal inhibitory concentration: 3470 nM
The estimate for compound 3 lay 1.2-fold (0.06 log units) below the measured number, within the range that was stated.
By their numbers in this assay, from the lowest: compounds 1, 2 and 3 (each within the scatter of the next).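

In this assay, putting the group of 4 heavy atoms (2 carbon, 1 nitrogen, 1 oxygen) in place of azidomethyl gives a 1.1-fold higher number from compound 2 to compound 3 (0.05 log units; within the scatter), and putting it in place of the larger group with the six-membered ring gives a 1.2-fold higher number from compound 1 to compound 3 (0.07 log units; within the scatter). The earlier pair differed only in what the saturated chain carbon carried, whereas compound 3 no longer has that carbon, so the series now shows that replacing the carbon itself on the double-bonded ring carbon also stays within the scatter, and compounds 1, 2 and 3 cannot be told apart on this read-out. No available measurement offers an explanation for this result.

As far as these compounds go, what remains open is whether any group on this ring carbon would move the read-out beyond the scatter, for example a carboxylic acid, a primary amine or a longer alkyl chain. From the compounds shown here alone, it is also open whether the shared core responds in the same way elsewhere, such as on replacing the ((2-methylprop-1-en-1-yl)carbonyl)oxy group with a hydroxy group.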